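The source may report more compounds than this note shows. Statements on the series, on what has been measured and on what is new or still open speak of the compounds shown alone.

Measured so far in an assay on cells for inhibition of Voltage-dependent T-type calcium channel subunit alpha-1G (Homo sapiens), read by patch clamp, tested at 10 uM; a lower number here means less inhibition, a higher number more inhibition at the concentration tested (going by the name of the read-out):
- compound 1, `O=C(CC1c2ccccc2N=C(SCCCCCN2CCCC2)N1c1ccc(-c2ccccc2)cc1)NCc1ccc(F)cc1`: 51.5%
- compound 2, `CN(C)CCCCCSC1=Nc2ccccc2C(CC(=O)NCc2ccccc2)N1c1ccc(-c2ccccc2)cc1`: 76.2%
- compound 3, `O=C(CC1c2ccccc2N=C(SCCCCCN2CCCC2)N1c1ccc(-c2ccc(F)cc2)cc1)NCc1ccccc1`: 83.9%

Among these three, compound 3 carries the highest number. Compound 2 stands nearest to it, a gap that lies within the usual scatter of such measurements, so the two cannot be ranked against each other. Compound 1 stands furthest off, and that gap lies beyond the scatter.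

Compound 4, `O=C(CC1c2ccccc2N=C(SCCCCCN2CCCC2)N1c1ccc(-c2ccccc2)cc1)NCc1ccccc1`, has not been measured. It is compound 3 with one change: hydrogen in place of fluoro on an aromatic carbon. The fluoro leaves from an aromatic carbon of a six-membered aromatic ring of carbon only, para to a large group, and a hydrogen takes its place; seen one bond further out, a 4-fluorophenyl becomes a phenyl. For the measured compounds named here, no pair of measured compounds differs by just this change, so no measured step shows what it does. Compound 1 and compound 2 differ from compound 3 in other places, and their values speak only for themselves.

With the shared core intact, he expects a small downward step from a number 11.9 percentage points lower from compound 3 to compound 4 (beyond the scatter) in this assay, of a size that may not clear the scatter. His estimate for compound 4 is 72%, in a range from 52% to 88%.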

Compound 4, a percentage reported as inhibition, at one concentration (the size of the read-out at that concentration, not a potency): 93.9%
Compound 4: the middle estimate sits 21.9 percentage points below what was measured; the whole stated range lies below it.
By their numbers in this assay, from the lowest: compound 1; then compounds 2, 3 and 4 (each within the scatter of the next, the first and the last beyond it).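

In this assay, taking the fluoro off the aromatic carbon para to a large group, so that the 4-fluorophenyl becomes a phenyl, gives a number 10 percentage points higher from compound 3 to compound 4 (within the scatter), and at this position the two compounds cannot be told apart. For the compounds shown here, the same exchange of hydrogen for fluoro on the aromatic ring at the amide end of the molecule gives a number 42.4 percentage points higher from compound 1 to compound 4 (beyond the scatter), so the two fluoro positions do not read alike, and the amide-end fluoro is the one with a step beyond the scatter. Going by these compounds alone, compound 4 also gives the first clean reading at the amine end of the chain, where pyrrolidin-1-yl in place of dimethylamino gives a number 17.7 percentage points higher from compound 2 to compound 4 (beyond the scatter), and no measurement available here bears on why these steps differ in size.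

The compounds shown leave open what a chlorine or a methoxy would do on the aromatic carbon that carries the fluoro in compound 3. They also leave open how a piperidin-1-yl at the chain end, or a shorter chain between the sulfur and the amine, would read in this assay.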